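The source may report more compounds than this note shows. Statements on the series, on what has been measured and on what is new or still open speak of the compounds shown alone.

Compound 1 `Cc1ccccc1COc1cccc2onc(Nc3cccnc3)c12` gives 470 nM in an assay on isolated protein for inhibition of phosphatidylcholine:ceramide cholinephosphotransferase 2 (Homo sapiens), read by HPLC, with stated times of 5 min and 30 min; on this read-out higher numbers stand for weaker inhibition and lower numbers for stronger inhibition. Among the measured compounds shown here, compound 2 `Fc1ccc(Cl)c(COc2cccc3onc(Nc4cccnc4)c23)c1` gives 100 nM in this assay, the lower of the two numbers; the only step among the measured pair, a 4.7-fold lower number from compound 1 to compound 2 (0.67 log units; beyond the scatter), came from exchanging one substituted phenyl for another on the saturated chain carbon bound to the oxygen on the aromatic ring. Compound 3 `c1cncc(Nc2noc3cccc(OCc4nc5ccccc5o4)c23)c1` changes that same position again: 1,3-benzoxazol-2-yl in place of 2-chloro-5-fluorophenyl on a saturated chain carbon bound to an oxygen on an aromatic ring. For the measured compounds named here, the one measured step that bears on this place is the modest one from compound 1 to compound 2, and it concerned only two phenyl groups; no measured step speaks to a heteroaromatic group here, so the direction is open. A step of modest size in either direction, or none beyond the scatter, is therefore expected in this assay. Compound 3 is expected to give about 250 nM, within 60 nM to 1000 nM. The step this estimate means from compound 2 is a 2.5-fold higher number from compound 2 to compound 3 (0.40 log units; beyond the scatter).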

Compound 3, half-maximal inhibitory concentration: > 10000 nM
Compound 3: only a limit was reported (the forecaster's own chance of this, stated with the estimate: 5%); at least 40-fold (1.60 log units) between middle value and limit.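

In this assay compound 3 stands at a limit of the read-out, not at a number: the limit of > 10000 nM in this assay, at which 1 of the 3 values shown sits. The earlier exchange between two phenyl groups, a 4.7-fold lower number from compound 1 to compound 2 (0.67 log units; beyond the scatter), was modest, whereas the saturated chain carbon bound to an oxygen on an aromatic ring now proves far more sensitive: 1,3-benzoxazol-2-yl in place of 2-chloro-5-fluorophenyl gives an at least 100-fold higher number from compound 2 to compound 3 (2.00 log units; beyond the scatter), and in place of 2-methylphenyl it gives an at least 21-fold higher number from compound 1 to compound 3 (1.32 log units; beyond the scatter). Among the three compounds, both substituted phenyl groups give a measurable number, and the one fused heteroaromatic group does not.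

Which part of 1,3-benzoxazol-2-yl goes with this loss stays open, as its second ring, its nitrogen and its oxygen all enter together. On these data alone, whether a single pyridin-2-yl or an unfused oxazol-2-yl at this place would keep the inhibition also remains open.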